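Cyano in Place of Trifluoromethyl: Expected Weak Inhibition

The source may hold more compounds than are shown below. What is called first, only, known or untested is meant among the compounds shown, and "the series" means these compounds.

Measured so far:
Compound 1, `Cc1n[nH]c(C(=O)O)c1Cc1cccc(C(N)=O)c1`: 8%
Compound 2, `Cc1n[nH]c(C(=O)O)c1Cc1cccc(C(F)(F)F)c1`: 5%

In an assay on isolated protein for inhibition of 2-Hydroxyacid oxidase 2 (Homo sapiens), tested at 1 uM (on this read-out higher numbers stand for a stronger effect at the one concentration tested and lower numbers for a weaker effect), compound 1 gives 8% and compound 2 gives 5%. Compound 2 holds the lowest of these two numbers, but the step of a number 3 percentage points lower from compound 1 to compound 2 (within the scatter) lies within the scatter, so the two compounds cannot be ranked against each other; both show only weak inhibition. Compound 3, `Cc1n[nH]c(C(=O)O)c1Cc1cccc(C#N)c1`, has not yet been measured. It differs from compound 2 in one place: cyano in place of trifluoromethyl on an aromatic carbon. Within the data shown here, the only measured step that bears on this change is a number 3 percentage points lower from compound 1 to compound 2 (within the scatter), an exchange of the group on an aromatic carbon that produced no shift beyond the scatter. On that basis, compound 3 is expected to remain a weak inhibitor, and the expected step of a number 1 percentage points higher from compound 2 to compound 3 (within the scatter) in this assay is none beyond the scatter. Compound 3 is therefore estimated at 6%, within a range from 0% to 16%.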

Compound 3, a percentage reported as inhibition, at one concentration (the size of the read-out at that concentration, not a potency): 6%
Estimate against measurement, compound 3: no gap at the digits printed, within the range that was stated.
By their numbers in this assay, from the lowest: compounds 2, 3 and 1 (each within the scatter of the next).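

In this assay, cyano as a third group on this aromatic carbon gives a number 1 percentage points higher from compound 2 to compound 3 (within the scatter), and set against carbamoyl it gives a number 2 percentage points lower from compound 1 to compound 3 (within the scatter), so none of the three groups can be ranked against the others. Trifluoromethyl has 4 heavy atoms and 0 hydrogen-bond acceptors, while cyano has 2 heavy atoms and 1 hydrogen-bond acceptor, yet this exchange, on a six-membered aromatic ring of carbon only and meta to a large group, moves the number by no more than the scatter. No measurement at hand explains this lack of change.

The compounds shown leave open whether an amine, a carboxylic acid or a longer chain on this carbon would shift the number beyond the scatter. They also leave open whether changes elsewhere on the shared core would matter more than changes at this position.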